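Aryl removal in a thioamide series: rat stomach dose

The source may hold more compounds than are shown below. What is called first, only, known or untested is meant among the compounds shown, and "the series" means these compounds.

Measured so far in a functional assay on the whole organism (stomach) with Rattus norvegicus as the target; a higher number here means that more compound is needed for the effect, a lower number that less compound is needed:
- compound 1 `N=C(S)CCn1nc(-c2cccs2)ccc1=O`: 100 mg/kg
- compound 3 `N=C(S)CCn1nc(-c2ccc(Cl)c(Cl)c2)ccc1=O`: 78.1 mg/kg
- compound 2 `Cc1ccc(=O)n(CCCC(=N)S)n1`: > 100 mg/kg, a limit of this assay, not a number

In this assay compound 1 gives the higher of the two numbers, and its nearest neighbour compound 3 sits within the scatter of it, so no order between the two can be read. For compound 2 only a limit is known, (the limit of > 100 mg/kg in this assay, at which 1 of the 3 values shown sits).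

Compound 4 `N=C(S)CCn1ncccc1=O` has not been measured. It differs from compound 1 in one place: hydrogen in place of thiophen-2-yl on an aromatic carbon. Going by the values given here, no measured pair isolates this change, so its size is unknown here. The expectation is a step toward more compound needed, a 1.6-fold higher number from compound 1 to compound 4 (0.20 log units; within the scatter), with a fair chance that only a limit results. Compound 4 is estimated at 160 mg/kg, between 60 mg/kg and 400 mg/kg.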

Compound 4, dose for half-maximal effect: > 100 mg/kg
Compound 4: only a limit was reported (the forecaster's own chance of this, stated with the estimate: 50%); the middle value does not contradict the limit.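

In this assay, hydrogen in place of thiophen-2-yl on the aromatic carbon gives a number no lower from compound 1 to compound 4 (the limit leaves the size open). Taking the thiophen-2-yl off this carbon therefore brings no lower dose, which the earlier compounds could not show, since no measured pair isolated this change. Compound 4 gives a limit, not a number, and it is the second compound at that limit: the limit of > 100 mg/kg in this assay, at which 2 of the 4 values shown sit.

As far as these compounds go, how far the number moves with this change stays open. Also open, from the compounds shown here alone, is whether an amine or a methoxy group on this carbon would give a readable number.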